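Cytotoxicity notes on a chloroquinoline-thiophene series

The source may report more compounds than this note shows. Statements on the series, on what has been measured and on what is new or still open speak of the compounds shown alone.

Measured compounds:
compound 1 `Cc1ccc(-c2ccc(CNCCNc3ccnc4cc(Cl)ccc34)s2)cc1` with 2300 nM
compound 2 `Cc1ccc(-c2ccc(CNCCCNc3ccnc4cc(Cl)ccc34)s2)cc1` with 1290 nM

In an ADME assay on PBMC cells (Homo sapiens) for cytotoxicity, read by MTT assay, with a stated time of 48 h (on this read-out higher numbers stand for weaker inhibition and lower numbers for stronger inhibition), compound 2 gives 1290 nM. Compound 1 gives 2300 nM in this assay, and the two values lie within the scatter of each other, so no order between them can be read. Compound 3 `CC(=O)Nc1ccc(-c2ccc(CNCCCNc3ccnc4cc(Cl)ccc34)s2)cc1` is not yet measured in this assay. It differs from compound 2 by acetamido in place of methyl on an aromatic carbon. Within the data shown here, no measured pair shows a comparable change, so there is no basis for a directed step; a shift of no more than the scatter is expected. The estimate for compound 3 in this assay is 1800 nM (range 600 nM to 6000 nM), which corresponds to the expected step of a 1.4-fold higher number from compound 2 to compound 3 (0.14 log units; within the scatter).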

Compound 3, half-maximal inhibitory concentration: 2080 nM
The estimate for compound 3 lay 1.2-fold (0.06 log units) below the measured number, within the range that was stated.
By their numbers in this assay, from the lowest: compounds 2, 3 and 1 (each within the scatter of the next).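

In this assay, among these compounds, acetamido in place of methyl on an aromatic carbon para to a large group gives a 1.6-fold higher number from compound 2 to compound 3 (0.21 log units; within the scatter), the first reading of a change at this position. The added heavy atoms, hydrogen-bond donor and hydrogen-bond acceptor therefore come with no readable shift in the number. No measurement on hand bears on this result. Still open, going by these compounds, is whether a carboxylic acid or an amine at this position would move the number beyond the scatter, and whether acetamido behaves alike on the chain of compound 1.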